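The source may hold more compounds than are shown below. What is called first, only, known or untested is meant among the compounds shown, and "the series" means these compounds.

Measured so far:
Compound 1, `CCOC(=O)c1cc2ccc(OCCCCCn3cc(CNC(=O)CCCCC4CCSS4)nn3)cc2oc1=O`: 39.5%
Compound 2, `COc1ccc(-c2cc3ccc(OCCCCCn4cc(CNC(=O)CCCCC5CCSS5)nn4)cc3oc2=O)cc1OC`: 51.9%

In a functional assay on PC-12 cells (Rattus norvegicus) for cytotoxicity, read by MTT assay, with stated times of 3 h and 2 h, tested at 20 uM (a lower number here means a weaker effect, a higher number a stronger effect of the compound at the concentration tested), compound 2 gives 51.9%, the higher of the two numbers, while compound 1 gives 39.5%. For the measured compounds named here, the only measured step, a number 12.4 percentage points higher from compound 1 to compound 2 (beyond the scatter), put an aryl group where an ester had been. Compound 3, `O=C(CCCCC1CCSS1)NCc1cn(CCCCCOc2ccc3cc(-c4ccc(Br)cc4)c(=O)oc3c2)nn1`, differs from compound 2 at that same place: 4-bromophenyl in place of 3,4-dimethoxyphenyl on an aromatic carbon. Here one aryl group replaces another, so the earlier step bears on this change only loosely, and no move beyond the scatter is expected. Compound 3 is therefore expected to give about 50%, in the range 36% to 64%. This corresponds to an expected step of a number 1.9 percentage points lower from compound 2 to compound 3 (within the scatter).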

Compound 3, a percentage reported as activity, at one concentration (the size of the read-out at that concentration, not a potency): 52.3%
Compound 3: middle estimate off by 2.3 percentage points, on the low side, within the range that was stated.
By their numbers in this assay, from the lowest: compound 1; then compounds 2 and 3 (each within the scatter of the next).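

In this assay, putting 4-bromophenyl in place of 3,4-dimethoxyphenyl gives a number 0.4 percentage points higher from compound 2 to compound 3 (within the scatter), so at this position these two aryl groups cannot be told apart, even though one carries bromine and the other two methoxy groups. Putting 4-bromophenyl in place of ethoxycarbonyl gives a number 12.8 percentage points higher from compound 1 to compound 3 (beyond the scatter), which means that both aryl compounds now stand clear of the ester compound. Nothing available explains these readings.

Going by these compounds, whether a plain phenyl, a pyridine ring or an amine at this position would read like the two aryl compounds stays open. Taken at a single concentration, these numbers also say nothing about potency.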